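The source may report more compounds than this note shows. Statements on the series, on what has been measured and on what is new or still open speak of the compounds shown alone.

In an assay for inhibition of Amine oxidase [flavin-containing] B (Rattus norvegicus) (on this read-out higher numbers stand for weaker inhibition and lower numbers for stronger inhibition), compound 1 `COc1ccc(COc2ccc(-c3nn(CCC#N)c(=O)o3)cc2)cc1` gives 27 nM, and compound 2 `Cc1ccc(COc2ccc(-c3nn(CCC#N)c(=O)o3)cc2)cc1` gives 15 nM. These two differ by methyl in place of methoxy on an aromatic carbon, a change that made a 1.8-fold lower number from compound 1 to compound 2 (0.26 log units; within the scatter). Compound 3 `COc1cccc(COc2ccc(C3=NN(CCC#N)C(=O)CO3)cc2)c1` rests on another core; the difference between the two cores is not broken down here. In this assay compound 3 gives 68 nM, the highest number of the three. Compound 4 `Cc1cccc(COc2ccc(C3=NN(CCC#N)C(=O)CO3)cc2)c1` differs from compound 3 by methyl in place of methoxy on an aromatic carbon. This is the same kind of change as the earlier one, but the group now sits meta to a large group, where before it sat para to a large group. Because that earlier change made only a 1.8-fold lower number from compound 1 to compound 2 (0.26 log units; within the scatter), a small step is expected here as well, a 1.7-fold lower number from compound 3 to compound 4 (0.23 log units; within the scatter). Compound 4 is therefore estimated at 40 nM, most likely between 20 nM and 110 nM.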

Compound 4, half-maximal inhibitory concentration: 31 nM
Estimate against measurement, compound 4: 1.3-fold (0.11 log units) above; measured number inside the range.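

In this assay, methyl in place of methoxy gave a 2.2-fold lower number from compound 3 to compound 4 (0.34 log units; beyond the scatter), and the size of this step held from the core of compound 1 to the core of compound 3: the same change on two cores in this assay, a 1.8-fold lower number (0.26 log units; within the scatter) from compound 1 to compound 2 and a 2.2-fold lower number (0.34 log units; beyond the scatter) from compound 3 to compound 4, 1.2-fold (0.09 log units) apart, within the scatter of two such steps. The two steps therefore give no sign that the core alters the size of this change, although only the second lies beyond the scatter. Core and the place of the group differ together between the two pairs, so their contributions cannot be separated, and two pairs do not show that the step would hold on any further core.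

The compounds shown leave open how a chlorine or a hydroxyl at this place would compare with methyl and methoxy. They also leave open what would follow if an amine or a carboxylic acid took the place of the nitrile.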